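The source may report more compounds than this note shows. Statements on the series, on what has been measured and on what is new or still open speak of the compounds shown alone.

Measured compounds:
compound 1 `COc1ccc(-n2cc(NC(=O)c3cccc(NS(=O)(=O)c4ccc(Cl)cc4)c3)cn2)cc1` gives 8720 nM in a functional assay on MCF7 cells (Homo sapiens) for inhibition, read by MTT assay, with a stated time of 48 h; a higher number here means a weaker inhibitor, a lower number a stronger inhibitor
compound 2 `COc1cccc(-n2cc(NC(=O)c3cccc(NS(=O)(=O)c4ccc(Cl)cc4)c3)cn2)c1` gives 9430 nM in this assay
compound 3 `COc1ccc(-n2cc(NC(=O)c3ccc(NS(=O)(=O)c4ccccc4)cc3)cn2)cc1` gives 25600 nM in this assay

Compound 1 and compound 2 share a core and differ by 3-methoxyphenyl in place of 4-methoxyphenyl on an aromatic nitrogen. That change gives a 1.1-fold higher number from compound 1 to compound 2 (0.03 log units; within the scatter), so the two values cannot be told apart. Compound 3 is built on a different core; the difference between the two cores is not broken down here. Its number is the highest of the three, and the gap from compound 3 to either compound 1 or compound 2 is beyond the scatter.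

Compound 4 `COc1cccc(-n2cc(NC(=O)c3ccc(NS(=O)(=O)c4ccccc4)cc3)cn2)c1` is not yet measured. It differs from compound 3 by 3-methoxyphenyl in place of 4-methoxyphenyl on an aromatic nitrogen, the same change as from compound 1 to compound 2, made at the same place. For the measured compounds named here, with only that one earlier example to rest on, the expectation is that the step will again be small, about a 1.1-fold higher number from compound 3 to compound 4 (0.02 log units; within the scatter), because compound 1 to compound 2 gave a 1.1-fold higher number from compound 1 to compound 2 (0.03 log units; within the scatter). In this assay compound 4 is therefore expected to give about 27000 nM, with a plausible range from 14000 nM to 55000 nM.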

Compound 4, half-maximal inhibitory concentration: 28400 nM
Compound 4: the middle estimate sits 1.1-fold (0.02 log units) below what was measured; measured number inside the range.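

Placing 3-methoxyphenyl in place of 4-methoxyphenyl on the aromatic nitrogen gives a 1.1-fold higher number from compound 3 to compound 4 (0.05 log units; within the scatter) in this assay, so compound 3 and compound 4 cannot be told apart. The same change on the core of compound 1 and on the core of compound 3 gives steps that agree: the same change on two cores in this assay, a 1.1-fold higher number (0.03 log units; within the scatter) from compound 1 to compound 2 and a 1.1-fold higher number (0.05 log units; within the scatter) from compound 3 to compound 4, 1.0-fold (0.01 log units) apart, within the scatter of two such steps This shows that, on these two cores and in this assay, the choice between the two methoxyphenyl groups is not detectable; it does not show that the same would hold on a third core or in any other assay, and two pairs give no reason for the result.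

The compounds shown leave open whether a different group on the aromatic nitrogen, such as a phenyl ring bearing a carboxylic acid or an amine, or a plain longer chain, would give a step beyond the scatter. Also open is which of the differences between the two cores accounts for the gap between their numbers.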